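Swapping a Benzene Ring for a Pyridine in a Urea Series

The source may hold more compounds than are shown below. What is called first, only, known or untested is meant among the compounds shown, and "the series" means these compounds.

Compound 2, with structure `O=C(Nc1cc(Cl)cc(Cl)c1)NC1CCN(C/C2=C/CCCCCC2)CC1`, holds the lower of the two numbers recorded so far in a functional assay on CHO cells for antagonist activity at C-X-C chemokine receptor type 3 (Homo sapiens), read by GTPgammaS binding (a lower number here means a stronger inhibitor, a higher number a weaker inhibitor), where compound 2 gives 41 nM. Among the measured compounds shown here, its only neighbour, compound 1 with structure `O=C(Nc1cccc(OC(F)(F)F)c1)NC1CCN(C/C2=C/CCCCCC2)CC1`, gives 104 nM in this assay, a gap that lies beyond the usual scatter of repeated runs. Compound 3, with structure `O=C(Nc1c(Cl)cncc1Cl)NC1CCN(C/C2=C/CCCCCC2)CC1`, has not yet been tested. The change from compound 2 to compound 3 is 3,5-dichloropyridin-4-yl in place of 3,5-dichlorophenyl on an amide-type nitrogen. For the measured compounds named here, no measured pair in this set shows that kind of swap, so the size of its effect is unknown. The ring keeps both chlorines and its overall shape, so the expected step from compound 2 to compound 3 is small, a 1.5-fold higher number from compound 2 to compound 3 (0.17 log units; within the scatter), and may sit within the scatter. On that basis compound 3 is estimated at 60 nM, with a likely range from 20 nM to 200 nM.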

Compound 3, inhibition constant: 3400 nM
Compound 3: middle estimate off by 57-fold (1.75 log units), on the low side; measured number outside the range, above it.
By their numbers in this assay, from the lowest: compound 2; then compound 1; then compound 3.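

In this assay, the aryl group on this urea nitrogen proves highly sensitive to a single atom: replacing one ring carbon with nitrogen gives an 83-fold higher number from compound 2 to compound 3 (1.92 log units; beyond the scatter). The 3,5-dichlorophenyl and 3,5-dichloropyridin-4-yl groups have the same number of heavy atoms and both carry the two chlorines, yet the entering ring's one hydrogen-bond acceptor comes with a large loss of inhibition, so keeping the ring's overall shape does not preserve activity here. No measurement shown here accounts for the size of this step.

This single pair cannot show whether the loss applies to any ring nitrogen in this series or only to this dichloro pattern. A pyridine ring carrying methyl groups or fluorine atoms in place of the chlorines would help separate those possibilities.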